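Chlorinated benzoic acid replaces the oxymethylene-linked benzoate

This account rests on a few compounds, and the source may have more. Where it says the series, first, only, none or still open, it means among the compounds named here.

Compound 2 `Cc1c(OCCCCOCOc2ccc(C(=O)O)cc2)ccc(C(=O)CC2CCCC2)c1O` is one of two compounds in the series with a numerical result in an assay on HEK293 cells for positive allosteric modulation of metabotropic glutamate receptor 2 (Rattus norvegicus), read by thallium flux, with a stated time of 2.5 min; on this read-out higher numbers stand for an effect only at larger amounts of compound and lower numbers for an effect already at smaller amounts; in this assay compound 2 gives 228 nM, the higher of the two numbers. Its nearest neighbour, compound 1 `Cc1c(OCCCCOc2ccc(C(=O)CC(C)(C)C)c(O)c2C)cccc1C(=O)O`, gives 136 nM in this assay, and the gap between compound 1 and compound 2 lies within the scatter, so no order between them is claimed. Compound 3 `Cc1c(OCCCCOc2ccc(C(=O)O)cc2)ccc(C(=O)CC(C)C)c1C` gives "not determined" (no result reported) in this assay, so no number is reported for it.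

Compound 4 `Cc1c(OCCCCOc2ccc(C(=O)O)c(Cl)c2)ccc(C(=O)CC2CCCC2)c1O` differs from compound 2 in one place (4-carboxy-3-chlorophenyl in place of (4-carboxyphenoxy)methyl on an oxygen on a saturated carbon). Going by the values given here, no measured pair covers this change, so the size of the step rests on general expectation only. Given that compound 2 gives 228 nM in this assay, the step from compound 2 to compound 4 is expected to be small, with no direction that can be stated beyond the scatter, a 1.4-fold lower number from compound 2 to compound 4 (0.15 log units; within the scatter). Compound 4 is therefore estimated at 160 nM in this assay, within a range from 50 nM to 550 nM.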

Compound 4, half-maximal effective concentration: 510 nM
Compound 4: the middle estimate sits 3.2-fold (0.50 log units) below what was measured; the range from low to high includes it.
By their numbers in this assay, from the lowest: compounds 1 and 2 (each within the scatter of the next); then compound 4.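

In this assay, going by these compounds alone, this is the first readable step: on an oxygen on a saturated carbon, 4-carboxy-3-chlorophenyl in place of (4-carboxyphenoxy)methyl gives a 2.2-fold higher number from compound 2 to compound 4 (0.35 log units; beyond the scatter) and so counts as a modest loss. The position is therefore sensitive to this swap, even though a carboxylic acid on an aromatic ring is present on both sides of the change. No measurement available here explains the shift.

The single step removes the linking oxygen and methylene and adds a chlorine, so the compounds shown do not separate these two parts of the change. As far as these compounds go, it remains open whether a 4-carboxyphenyl without the chlorine, or one carrying a fluorine or a methyl in its place, would give a step of the same size.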